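Para-substituent swap on the thiourea aryl ring

This account rests on a few compounds, and the source may have more. Where it says the series, first, only, none or still open, it means among the compounds named here.

The shared core carries a thiourea linked to a substituted aryl ring. Compound 1 `OC(c1ccccc1)(c1ccccc1)C1CCN(C(=S)Nc2ccc(OC(F)(F)F)cc2)CC1` bears trifluoromethoxy on that ring and gives 1050 nM in a functional assay for antagonist activity at Neuropeptide Y receptor type 2 (Homo sapiens); a lower number here means a stronger inhibitor, a higher number a weaker inhibitor. Compound 2 `CCCc1ccc(NC(=S)N2CCC(C(O)(c3ccccc3)c3ccccc3)CC2)cc1` carries propyl in the same place and gives 777 nM in this assay. The step of a 1.4-fold lower number from compound 1 to compound 2 (0.13 log units; within the scatter) shows that these two substituents give numbers that cannot be told apart. Compound 2 thus holds the lowest of the two numbers, but its nearest neighbour, compound 1, sits within the scatter, so no order is established.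

Compound 3 `OC(c1ccccc1)(c1ccccc1)C1CCN(C(=S)Nc2ccc(C(F)(F)F)cc2)CC1` is the next member. Relative to compound 2 the change is trifluoromethyl in place of propyl on an aromatic carbon. For the measured compounds named here, the only step that bears on this change is the one from compound 1 to compound 2, an exchange of substituents in the same position, and it stayed within the scatter. On that basis the step of a 1.2-fold higher number from compound 2 to compound 3 (0.06 log units; within the scatter) is expected to stay within the scatter as well, in this assay. Compound 3 is therefore estimated at 900 nM, with a range from 400 nM to 2000 nM.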

Compound 3, half-maximal inhibitory concentration: 178 nM
Beside the measured number, compound 3's estimate is 5.1-fold (0.70 log units) above it; the measured number lies below the stated range.
By their numbers in this assay, from the lowest: compound 3; then compounds 2 and 1 (each within the scatter of the next).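

Substituent identity at this place, on the aromatic carbon para to a large group, does register in this assay: the step of a 4.4-fold lower number from compound 2 to compound 3 (0.64 log units; beyond the scatter) and the step of a 5.9-fold lower number from compound 1 to compound 3 (0.77 log units; beyond the scatter) both lie beyond the scatter, although both remain modest, whereas the earlier step of a 1.4-fold lower number from compound 1 to compound 2 (0.13 log units; within the scatter) separated nothing. Trifluoromethyl therefore stands apart from both propyl and trifluoromethoxy, making compound 3 the strongest inhibitor of the three, and the fact that trifluoromethoxy also carries fluorine shows that the presence of fluorine alone does not sort this small set. No measurement shown here accounts for the separation of trifluoromethyl from the other two groups.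

Going by these compounds, three substituents at one place define no trend, so it remains open how a nitrile, a chlorine atom, an amine or a longer chain there would compare with trifluoromethyl in compound 3. On these data alone, it is also open whether the advantage of trifluoromethyl would carry over to a changed shared core, for example one with a urea in place of the thiourea.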